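Methoxy for Bromo on the Aromatic Ring

The source may hold more compounds than are shown below. What is called first, only, known or untested is meant among the compounds shown, and "the series" means these compounds.

In a functional assay (mast cells) for inhibition, with Rattus norvegicus as the target (on this read-out higher numbers stand for an effect only at larger amounts of compound and lower numbers for an effect already at smaller amounts), compound 1 (`CC1CC/C(=N\Nc2cccc(C(=O)O)c2)c2nccc(=O)n21`) gives 655000 nM, compound 2 (`CC1CC/C(=N\Nc2ccc(F)cc2)c2ncc(C(=O)O)c(=O)n21`) gives 1200 nM and compound 3 (`CC1CC/C(=N\Nc2ccc(Br)cc2)c2ncc(C(=O)O)c(=O)n21`) gives 2000 nM. Compound 3 thus stands within the scatter of compound 2 and far under compound 1. Compound 4 (`COc1ccc(N/N=C2\CCC(C)n3c2ncc(C(=O)O)c3=O)cc1`) carries methoxy in place of bromo on an aromatic carbon, para to a large group: methoxy in place of bromo on an aromatic carbon. Going by the values given here, the one measured step at this place is a 1.7-fold higher number from compound 2 to compound 3 (0.22 log units; within the scatter), bromo in place of fluoro. Among the compounds with values here, no methoxy compound has been measured, but a step within the scatter is expected here too, in neither direction. That expected step is a 1.1-fold lower number from compound 3 to compound 4 (0.05 log units; within the scatter). For compound 4 the estimate is 1800 nM, with an expected range of 600 nM to 5500 nM.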

Compound 4, half-maximal effective concentration: 128000 nM
Compound 4: the middle estimate sits 71-fold (1.85 log units) below what was measured, and the stated range ends below it.
By their numbers in this assay, from the lowest: compounds 2 and 3 (each within the scatter of the next); then compound 4; then compound 1.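

The position proved far from indifferent to its substituent: in this assay, the change from 4-bromophenyl to 4-methoxyphenyl gives a 64-fold higher number from compound 3 to compound 4 (1.81 log units; beyond the scatter) and methoxy in place of fluoro gives a 110-fold higher number from compound 2 to compound 4 (2.03 log units; beyond the scatter) on the same core. Fluoro and bromo lie within the scatter of each other, so only methoxy revealed how much this place can matter. Nothing available explains the size of these steps. From the compounds shown here alone, it remains open whether a methyl, a hydroxyl or an ethoxy here would stand with the halogens or with methoxy.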